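Sulfonamide series at the chemokine receptor: compound 4

This account rests on a few compounds, and the source may have more. Where it says the series, first, only, none or still open, it means among the compounds named here.

Measured so far:
compound 1 `CC(C)(C)c1ccc(S(=O)(=O)Nc2ccc(Cl)cc2-c2ncccc2CO)cc1`: 89 nM
compound 2 `CC(C)(C)c1ccc(S(=O)(=O)Nc2ccc(Cl)cc2-c2c(O)ccc[n+]2[O-])cc1`: 491 nM
compound 3 `CC(C)(C)c1ccc(S(=O)(=O)Nc2ccc(Cl)cc2-c2ncnc(CO)c2O)cc1`: 11 nM

All three numbers come from a functional assay on isolated protein for antagonist activity at C-C chemokine receptor type 9 (Homo sapiens), read by calcium flux, with a stated time of 10 min; a lower number here means a stronger inhibitor, a higher number a weaker inhibitor. Compound 1 stands second highest of the three: nearest is compound 2, with a 5.5-fold higher number from compound 1 to compound 2 (0.74 log units; beyond the scatter); furthest is compound 3, with an 8.1-fold lower number from compound 1 to compound 3 (0.91 log units; beyond the scatter). Compound 4 `CNc1nccnc1-c1cc(Cl)ccc1NS(=O)(=O)c1ccc(C(C)(C)C)cc1` differs from compound 1 by 3-(methylamino)pyrazin-2-yl in place of 3-(hydroxymethyl)pyridin-2-yl on an aromatic carbon. Both measured steps from compound 1 alter the same ring, so both bear on this step, yet neither matches it: compound 2 and compound 3 each keep a hydroxyl or hydroxymethyl group, compound 4 keeps neither. The two steps pull in opposite directions, and a 45-fold lower number from compound 2 to compound 3 (1.65 log units; beyond the scatter) shows how wide the spread on this ring can be. The expectation is a step of a 1.5-fold lower number from compound 1 to compound 4 (0.17 log units; within the scatter), near the scatter. Compound 4 is therefore estimated at 60 nM, within 15 nM to 250 nM.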

Compound 4, half-maximal inhibitory concentration: 25 nM
Compound 4: middle estimate off by 2.4-fold (0.38 log units), on the high side; low and high end bracket the measured number.
By their numbers in this assay, from the lowest: compound 3; then compound 4; then compound 1; then compound 2.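

Without any oxygen on the ring, 3-(methylamino)pyrazin-2-yl still gives a 3.6-fold lower number from compound 1 to compound 4 (0.55 log units; beyond the scatter) and, on the larger scale, a 20-fold lower number from compound 2 to compound 4 (1.29 log units; beyond the scatter), so neither a hydroxyl nor a hydroxymethyl group is required for a low number at this position. Compound 3 remains the lowest of the four, with a 2.3-fold higher number from compound 3 to compound 4 (0.36 log units; beyond the scatter), so the oxygen-free ring does not fully match it. No available evidence accounts for these steps.

The change from compound 1 to compound 4 alters the ring and its substituent together, and their separate contributions cannot be read. Going by these compounds, how a dimethylamino group or a longer alkylamino chain would behave in place of methylamino remains open.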